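Methoxy removal and cytotoxicity in a small ester series

The source may report more compounds than this note shows. Statements on the series, on what has been measured and on what is new or still open speak of the compounds shown alone.

Compound 1 `COc1cc(/C=C/C(=O)O)ccc1OC(=O)c1nc(C)c(C)nc1C` and compound 3 `Cc1nc(C)c(C(=O)Oc2ccc(/C=C/C(=O)O)cc2)nc1C` share a core and differ by hydrogen in place of methoxy on an aromatic carbon. In a functional assay on EA.hy 926 cells (Homo sapiens) for cytotoxicity, read by MTT assay, with stated times of 24 h and 12 h, tested at 50 uM (on this read-out lower numbers stand for a weaker effect and higher numbers for a stronger effect at the one concentration tested), compound 1 gives 49.1%, while compound 3 gives 74.1%; the step is a number 25 percentage points higher from compound 1 to compound 3 (beyond the scatter). Compound 2 `CCOC(=O)/C=C/c1cc(OC)c(OC(=O)c2nc(C)c(C)nc2C)c(OC)c1` gives -13.6% in this assay, the lowest of the three numbers; the difference between the core of compound 2 and that of compound 1 is not broken down here. Compound 4 `CCOC(=O)/C=C/c1ccc(OC(=O)c2nc(C)c(C)nc2C)c(OC)c1` is unmeasured and differs from compound 2 by hydrogen in place of methoxy on an aromatic carbon, the same kind of change as from compound 1 to compound 3, though here the place is also meta to a methoxy group and meta to a 2-(ethoxycarbonyl)ethenyl group rather than a 2-carboxyethenyl group. Resting on the single earlier step of a number 25 percentage points higher from compound 1 to compound 3 (beyond the scatter) applied from the low value of compound 2, the step expected for compound 4 in this assay is a number 23.6 percentage points higher from compound 2 to compound 4 (beyond the scatter). Compound 4 is thus estimated at 10%, with a range from -15% to 40%.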

Compound 4, a percentage reported as activity, at one concentration (the size of the read-out at that concentration, not a potency): 69.7%
For compound 4 the middle estimate is 59.7 percentage points below the measured one, and the stated range ends below it.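

In this assay, hydrogen in place of methoxy on an aromatic carbon gives a number 83.3 percentage points higher from compound 2 to compound 4 (beyond the scatter), the same direction as the earlier step, but the size does not carry from one core to the other: the same change on two cores in this assay, a number 25 percentage points higher (beyond the scatter) from compound 1 to compound 3 and a number 83.3 percentage points higher (beyond the scatter) from compound 2 to compound 4, 58.3 percentage points apart, beyond the scatter of two such steps. Two pairs show a shared direction only; they give no size for this change on a further core and do not tell what sets the gap. Ethyl in place of hydrogen on an oxygen next to a carbonyl group gives a number 20.6 percentage points higher from compound 1 to compound 4 (beyond the scatter), a single pair that holds for this core alone.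

Still open, going by these compounds, is how the number moves with an ethoxy group or a chlorine in place of methoxy. Also open, on these data alone, is whether an amide or a longer ester chain in place of the ethyl ester would follow compound 4.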